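The source may report more compounds than this note shows. Statements on the series, on what has been measured and on what is new or still open speak of the compounds shown alone.

Measured so far, in a functional assay on CHO cells for antagonist activity at Orexin receptor type 2 (Homo sapiens), read by FLIPR and calcium flux; a higher number here means a weaker inhibitor, a lower number a stronger inhibitor:

compound 1 `CCn1nc(C)c2c1CCN(C(C(=O)NC)c1ccccc1)C2CCc1ccc(Cl)cc1` — 12 nM
compound 2 `CCn1nc(C)c2c1CCN(C(C(=O)NC)c1ccccc1)C2CCc1cccc(F)c1` — 10 nM
compound 3 `CCn1nc(C)c2c1CCN(C(C(=O)NC)c1ccccc1)C2CCc1ccc(C)cc1` — 6 nM

Among these three, compound 3 gives the lowest number, but its distance from the others is small: the step of a 2.0-fold lower number from compound 1 to compound 3 (0.30 log units; within the scatter) and the step of a 1.7-fold lower number from compound 2 to compound 3 (0.22 log units; within the scatter) both fall within the scatter, so no order among the three can be claimed.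

Compound 4 `CCn1nc(C)c2c1CCN(C(C(=O)NC)c1ccccc1)C2CCc1cccc(C)c1` differs from compound 3 in one place: 3-methylphenyl in place of 4-methylphenyl on a saturated chain carbon, two bonds along the chain from a saturated ring carbon. The aryl group on that chain carbon is the only part of the shared core that has been varied in this series, so all three earlier steps bear on the question. The step of a 1.2-fold lower number from compound 1 to compound 2 (0.08 log units; within the scatter) moved a substituent on that same ring from one position to another and changed the number only within the scatter; the step of a 1.7-fold lower number from compound 2 to compound 3 (0.22 log units; within the scatter) did the same in the other direction, again within the scatter. A methyl group was already tolerated on that ring in compound 3, and a substituent at the position now entered was tolerated in compound 2.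

Taken together, these steps suggest that moving the methyl group should leave the number in this assay about where compound 3 stands, with no step beyond the scatter in either direction; the expected step is a 1.3-fold higher number from compound 3 to compound 4 (0.12 log units; within the scatter). Compound 4 is therefore estimated at 8 nM, with a range from 3.5 nM to 18 nM.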

Compound 4, half-maximal inhibitory concentration: 19 nM
Beside the measured number, compound 4's estimate is 2.4-fold (0.38 log units) below it; measured number above the stated range.
By their numbers in this assay, from the lowest: compounds 3, 2, 1 and 4 (each within the scatter of the next, the first and the last beyond it).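

In this assay, among the compounds shown here, where the methyl group sits on the aryl ring turns out to matter: a 3.2-fold higher number from compound 3 to compound 4 (0.50 log units; beyond the scatter) is the only step beyond the scatter, and it arises from the same atoms joined differently, with 3-methylphenyl in place of 4-methylphenyl. It is modest, however, and it rests on this single pair. The other two new steps, a 1.9-fold higher number from compound 2 to compound 4 (0.28 log units; within the scatter) and a 1.6-fold higher number from compound 1 to compound 4 (0.20 log units; within the scatter) lie within the scatter, so 3-methylphenyl cannot be told apart from 3-fluorophenyl or from 4-chlorophenyl in this assay.

The compounds shown leave open whether the gap between the two methylphenyl groups is specific to methyl or would recur with another matched pair such as 3-chlorophenyl and 4-chlorophenyl, and where unsubstituted phenyl or 4-methoxyphenyl would fall. They also leave open whether the same gap would survive on a longer chain than the 2-arylethyl chain shared here. No measurement at hand offers an explanation for the difference between compound 3 and compound 4.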